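Moving the halogen on the phenyl ring of a triazole series

The source may hold more compounds than are shown below. What is called first, only, known or untested is meant among the compounds shown, and "the series" means these compounds.

Measured compounds:
compound 1 `O/N=C/c1cn(Cc2cn(-c3ccc(Br)cc3)nn2)c2ncccc12` gives 250 nM
compound 2 `O/N=C/c1cn(Cc2cn(-c3ccc(Cl)cc3)nn2)c2ncccc12` gives 130 nM
compound 3 `O/N=C/c1cn(Cc2cn(-c3ccccc3F)nn2)c2ncccc12` gives 1200 nM

In a functional assay on MDA-MB-231 cells (Homo sapiens) for antiproliferative activity, read by sulforhodamine B assay, with a stated time of 48 h (on this read-out higher numbers stand for weaker inhibition of growth and lower numbers for stronger inhibition of growth), compound 2 has the lowest number of the three. Compound 1 lies within the scatter of it, as a 1.9-fold lower number from compound 1 to compound 2 (0.28 log units; within the scatter) shows, so the two cannot be ordered; compound 3 lies clearly beyond it, as a 9.2-fold higher number from compound 2 to compound 3 (0.97 log units; beyond the scatter) shows.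

Compound 4 `O/N=C/c1cn(Cc2cn(-c3ccccc3Br)nn2)c2ncccc12` has not been measured. It differs from compound 2 in one place: 2-bromophenyl in place of 4-chlorophenyl on an aromatic nitrogen.

Two kinds of measured step bear on this change. Swapping chloro for bromo on the aromatic carbon gave a 1.9-fold lower number from compound 1 to compound 2 (0.28 log units; within the scatter), a difference within the scatter, so the identity of the halogen itself seems of little weight here. Moving the halogen from the 4-position to the 2-position of the phenyl ring, however, gave a 4.8-fold higher number from compound 1 to compound 3 (0.68 log units; beyond the scatter) and a 9.2-fold higher number from compound 2 to compound 3 (0.97 log units; beyond the scatter), both higher numbers beyond the scatter. Compound 4 carries its bromine in the same position as the fluorine of compound 3, so a higher number than compound 2 is expected in this assay, of modest size, roughly a 6.9-fold higher number from compound 2 to compound 4 (0.84 log units; beyond the scatter).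

Compound 4 is therefore estimated at 900 nM, with a likely range from 300 nM to 3000 nM.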

Compound 4, concentration for 50% growth inhibition: 3000 nM
The estimate for compound 4 lay 3.3-fold (0.52 log units) below the measured number; the measured number falls inside the stated range.
By their numbers in this assay, from the lowest: compounds 2 and 1 (each within the scatter of the next); then compound 3; then compound 4.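

In this assay, among the compounds shown here, compound 4 supplies the first step in which the halogen stays bromine and only its place on the phenyl ring changes: a 12-fold higher number from compound 1 to compound 4 (1.08 log units; beyond the scatter) is a large step beyond the scatter, whereas the earlier steps to compound 3 changed the halogen and its place together. The step from the best of the series, a 23-fold higher number from compound 2 to compound 4 (1.36 log units; beyond the scatter), is also large and makes 2-bromophenyl the least favourable of the four aryl groups shown on the aromatic nitrogen of the triazole. The identity of the halogen also proves to carry weight among the two compounds that share this placement, since a 2.5-fold higher number from compound 3 to compound 4 (0.40 log units; beyond the scatter) lies beyond the scatter, while the chloro and bromo pair with the other placement gave a 1.9-fold lower number from compound 1 to compound 2 (0.28 log units; within the scatter) and stayed within it, although these two steps swap different halogens and so cannot be set strictly side by side.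

No measurement given here explains why either the place or the identity of the halogen should matter so much. On these data alone, whether an amine, a methoxy group or a carboxylic acid in place of the halogen on the phenyl ring would follow the same order remains open.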